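Removing the Methyl from the Ring Amine of Compound 1

The source may hold more compounds than are shown below. What is called first, only, known or untested is meant among the compounds shown, and "the series" means these compounds.

Measured so far:
compound 1 `COc1cncc(C2=CC3CC(C2)CN(C)C3)c1`: 19%
compound 2 `C1=C(c2cccnc2)C[C@H]2CNC[C@@H]1C2`: 114%
compound 3 `Clc1ccc(C2=CC3CNCC(C2)C3)nn1`: 118%

In an in vitro functional assay on SH-EP1 cells for agonist activity at Neuronal acetylcholine receptor; alpha4/beta2 (Homo sapiens), read by FLIPR and calcium flux (on this read-out higher numbers stand for larger maximal responses and lower numbers for smaller maximal responses), compound 1 gives 19%, the lowest of the three numbers. Its nearest neighbour is compound 2, which gives 114%, a gap well beyond the scatter; the furthest is compound 3, which gives 118%, also well beyond the scatter. Compounds 2 and 3 lie within the scatter of each other.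

Compound 4 `COc1cncc(C2=CC3CNCC(C2)C3)c1` differs from compound 1 in one place: hydrogen in place of methyl on an amine nitrogen in a ring. Going by the values given here, no measured pair shows this step directly. Still, both compound 2 and compound 3 carry a hydrogen on the ring amine nitrogen, and each reaches a large maximal response, whereas compound 1 with the methyl group reaches 19%. From this the step is expected to be large and upward in this assay, beyond the scatter.

Compound 4 is therefore estimated to give 95% in this assay, with a range from 55% to 125%, an expected step of a number 76 percentage points higher from compound 1 to compound 4 (beyond the scatter).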

Compound 4, largest response reached (reported as percent of maximum), in percent of the reference or control that the assay uses: 72%
Beside the measured number, compound 4's estimate is 23 percentage points above it; measured number inside the range.
By their numbers in this assay, from the lowest: compound 1; then compound 4; then compounds 2 and 3 (each within the scatter of the next).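

Hydrogen in place of methyl on an amine nitrogen in a ring gives, in this assay, a number 53 percentage points higher from compound 1 to compound 4 (beyond the scatter), the first step in which this change stands alone in the core of compound 1. Compound 2 and compound 3 each differ from compound 1 in more than one place, so they could not isolate the methyl; this pair shows that this single carbon on the nitrogen separates a small maximal response from a much larger one. The data shown offer no measured explanation for the size of this step.

An ethyl or a cyclopropyl group on this nitrogen is not among the compounds shown, so it remains open how the response changes with other groups at this position. As far as these compounds go, it also remains open whether adding methyl to the ring amine of compound 2 or compound 3 would give a step of similar size.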